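The source may report more compounds than this note shows. Statements on the series, on what has been measured and on what is new or still open speak of the compounds shown alone.

Values in a functional assay on cells (Lymphocyte, Homo sapiens); on this read-out lower numbers stand for stronger inhibition and higher numbers for weaker inhibition:

compound 1 `CC(C)(Oc1ccc(Cl)cc1)C(=O)N1CCN(c2nc(N)nc3sc(-c4ccc(F)cc4)nc23)CC1`: > 10000 nM
compound 2 `Nc1nc(N2CCN(C(=O)OCc3ccccc3)CC2)c2nc(-c3ccc(F)cc3)sc2n1`: 4900 nM
compound 3 `Nc1nc(N2CCN(C(=O)COc3ccccc3)CC2)c2nc(-c3ccc(F)cc3)sc2n1`: 90 nM

The value of compound 1 is a limit of the assay, (the limit of > 10000 nM in this assay, at which 1 of the 3 values shown sits). Among the two numbers, compound 3 gives the lowest, with compound 2 the nearest at a 54-fold lower number from compound 2 to compound 3 (1.74 log units; beyond the scatter). The steps of an at least 2.0-fold lower number from compound 1 to compound 2 (0.30 log units; that floor lies within the scatter) and an at least 110-fold lower number from compound 1 to compound 3 (2.04 log units; beyond the scatter) both change the whole group on the carbonyl carbon at once.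

Compound 4 `COc1ccc(OCC(=O)N2CCN(c3nc(N)nc4sc(-c5ccc(F)cc5)nc34)CC2)cc1` differs from compound 3 by methoxy in place of hydrogen on an aromatic carbon. Among the measured compounds shown here, no measured step isolates a single substituent on that six-membered aromatic ring: compound 1 carries a chlorine on its ring, but it also lacks the phenoxymethyl of compound 3, so its change cannot be read on its own. Without a bearing step, no shift beyond the scatter is expected in this assay, and compound 4 is estimated at 120 nM, range 35 nM to 450 nM, a step of a 1.3-fold higher number from compound 3 to compound 4 (0.12 log units; within the scatter) that is expected to stay within the scatter.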

Compound 4, half-maximal inhibitory concentration: 40 nM
Beside the measured number, compound 4's estimate is 3.0-fold (0.48 log units) above it; the range from low to high includes it.
By their numbers in this assay, from the lowest: compound 4; then compound 3; then compound 2. At a limit, above all of these: compound 1.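

In this assay, a single substituent on the six-membered aromatic ring now has a step of its own: methoxy in place of hydrogen, para to a large group, gives a 2.3-fold lower number from compound 3 to compound 4 (0.35 log units; beyond the scatter). Carrying that methoxy, the (4-methoxyphenoxy)methyl group in place of benzyloxy on the carbonyl carbon gives a 120-fold lower number from compound 2 to compound 4 (2.09 log units; beyond the scatter). Compound 1 stands at a limit of the assay, so an at least 250-fold lower number from compound 1 to compound 4 (2.39 log units; beyond the scatter) is only a floor and changes the whole group on the carbonyl carbon at once: the limit of > 10000 nM in this assay, at which 1 of the 4 values shown sits.

As far as these compounds go, how a hydroxyl, an amine or a lone chlorine on that same aromatic carbon would compare with methoxy stays open. Compound 1 differs from compound 4 by more than its ring substituent, so the chlorine cannot be read on its own.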